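Trifluoromethoxy on the anilide ring of compound 1

A few compounds are considered here, and "the series" means these few. Any claim that something is new, unique, unknown or untested is made for them only; others in the source may bear on it.

Compound 1 `O=C(Nc1ccccc1)c1cc(F)ccc1O` is known in a functional assay on KG-1 cells (Homo sapiens) for cytotoxicity, read by luminescence and CellTiter-Glo, with a stated time of 3 days (a lower number here means a stronger inhibitor, a higher number a weaker inhibitor), only as a limit: compound 1 gives > 10000 nM, which is the limit of > 10000 nM in this assay, at which 1 of the 3 values shown sits. Compound 2 `N#Cc1ccc(NC(=O)c2cc(F)ccc2O)cc1` gives 2670 nM in this assay, and compound 3 `O=C(Nc1ccc(C(F)(F)F)cc1)c1cc(F)ccc1O` gives 1700 nM. Compound 4 `O=C(Nc1cccc(OC(F)(F)F)c1)c1cc(F)ccc1O` differs from compound 1 in one place: trifluoromethoxy in place of hydrogen on an aromatic carbon. Among the measured compounds shown here, two measured steps bear on it, each putting a group onto the same ring in place of hydrogen: an at least 3.7-fold lower number from compound 1 to compound 2 (0.57 log units; beyond the scatter) and an at least 5.8-fold lower number from compound 1 to compound 3 (0.76 log units; beyond the scatter), while a 1.6-fold lower number from compound 2 to compound 3 (0.20 log units; within the scatter). The change in compound 4 uses a different group at a different place, so a smaller gain is expected, an at least 2.2-fold lower number from compound 1 to compound 4 (0.34 log units; beyond the scatter). Compound 4 is therefore estimated at 4500 nM, with a range from 1500 nM to 13000 nM.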

Compound 4, half-maximal inhibitory concentration: 830 nM
For compound 4 the middle estimate is 5.4-fold (0.73 log units) above the measured one; the measured number lies below the stated range.
By their numbers in this assay, from the lowest: compound 4; then compounds 3 and 2 (each within the scatter of the next). At a limit, above all of these: compound 1.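

In this assay, a group placed meta to a large group on the anilide ring also lowers the number, with trifluoromethoxy in place of hydrogen giving an at least 12-fold lower number from compound 1 to compound 4 (1.08 log units; beyond the scatter). Among the compounds shown here, this is the first step printed as large, so this position accepts a substituent and need not lose activity. Compound 1 stands at a limit, so the step is only a floor: the limit of > 10000 nM in this assay, at which 1 of the 4 values shown sits.

The compounds shown do not separate the effect of the group from that of its place on the ring. As far as these compounds go, how an amine or a carboxylic acid would behave at this position also remains open.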